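The source may report more compounds than this note shows. Statements on the series, on what has been measured and on what is new or still open speak of the compounds shown alone.

Of the compounds shown here, three have so far been tested in a functional assay on MDA-MB-231 cells (Homo sapiens) for cytotoxicity, read by MTT assay, with a stated time of 72 h; a lower number here means a stronger inhibitor, a higher number a weaker inhibitor. Compound 1 `N=C(Nc1cccc(C(F)(F)F)c1)c1cc2c(-c3ccccc3)n[nH]c2cn1` gives 22300 nM there, the highest of the three numbers. Compound 3 `COc1ccc(Cn2cc3cc(C(=N)Nc4cccc(C(F)(F)F)c4)ncc3n2)cc1` gives 15500 nM, a number that sits within the usual scatter of the value of compound 1, so the two cannot be told apart. Compound 2 `COc1cc(Nc2nc(C(=N)Nc3ccccc3)cc3c(-c4ccccc4)n[nH]c23)cc(OC)c1OC` gives 4500 nM, and its gap to compound 1 lies beyond the scatter. Compound 4 `Cn1nc(-c2ccccc2)c2cc(C(=N)Nc3cccc(C(F)(F)F)c3)ncc21` has not been measured yet. It differs from compound 1 in a single place: methyl in place of hydrogen on an aromatic nitrogen. For the measured compounds named here, no pair of measured compounds shows what this particular change does, so the only guide is how small the addition is. The step expected here is a 1.1-fold higher number from compound 1 to compound 4 (0.05 log units; within the scatter), which stays within the scatter rather than moving clearly in either direction. Compound 4 is therefore expected to give about 25000 nM in this assay, with a likely range from 9000 nM to 70000 nM.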

Compound 4, half-maximal inhibitory concentration: 21400 nM
Compound 4: the middle estimate sits 1.2-fold (0.07 log units) above what was measured; the range from low to high includes it.
By their numbers in this assay, from the lowest: compound 2; then compounds 3, 4 and 1 (each within the scatter of the next).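

Within this assay the swap of hydrogen for methyl on this aromatic nitrogen gives a 1.0-fold lower number from compound 1 to compound 4 (0.02 log units; within the scatter) and so provides the first direct reading of a change at this position. In this assay, the hydrogen on that nitrogen of compound 1 can therefore be replaced by methyl without a detectable shift in the number. No measurement of any other kind is available to explain this result.

Methyl is the only replacement for that hydrogen shown here, so it remains open whether a longer chain such as propyl, or a chain ending in an amine or a carboxylic acid, would also leave the number within the scatter. Going by these compounds, it is also open whether methyl at this nitrogen would have the same small effect on compound 2 with its different substituents.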